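Acid dissociation in the diamine series: compound 4

This account rests on a few compounds, and the source may have more. Where it says the series, first, only, none or still open, it means among the compounds named here.

Measured compounds and their values:
compound 1, `COc1cccc(CNCCCNc2ccnc3cc(Cc4ccccc4)ccc23)c1O` — 9.47
compound 2, `Fc1ccc(Cc2ccc3c(NCCCNCc4ccco4)ccnc3c2)c(Cl)c1` — 9.47
compound 3, `COc1ccc(F)cc1CNCCCNc1ccnc2cc(Cc3ccccc3)ccc12` — 9.47

The read-out throughout is a physicochemical assay for acid dissociation. Compound 1 stands level with compounds 2 and 3 at the digits given; its nearest neighbour is compound 2 and its furthest is compound 3, and in neither case does the gap go beyond the usual scatter. Within the data shown here, compound 2 and compound 3 both return the same number as compound 1, so nothing among the measured set separates them.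

One measured step joins two of these compounds, no change at the digits printed from compound 1 to compound 3 (within the scatter): the group on the saturated chain carbon bound to an amine nitrogen was exchanged, and the value did not move beyond the scatter.

Compound 4 is `COc1cccc(CNCCCNc2ccnc3cc(-c4ccc(F)cc4)ccc23)c1O`. It differs from compound 1 in one place:
4-fluorophenyl in place of benzyl on an aromatic carbon

Among the measured compounds shown here, no measured step touches this part of the shared core; the only step available concerns the chain end and was flat. The three measured compounds, with their varied groups, all sit at one value, so a shift beyond the scatter is not expected here either. The expected step of a number 0.02 log units lower from compound 1 to compound 4 (within the scatter) is therefore essentially none. Compound 4 is estimated at 9.45, with a range from 9.1 to 9.8.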

Compound 4, acid dissociation constant: 9.47
For compound 4 the middle estimate is 0.02 log units below the measured one; measured number inside the range.
By their numbers in this assay, from the lowest: compounds 1, 2, 3 and 4 (each within the scatter of the next).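

In this assay, the aromatic carbon of the shared core, meta to a fused ring and para to a fused ring, now has a step of its own: 4-fluorophenyl in place of benzyl reads no change at the digits printed from compound 1 to compound 4 (within the scatter). Alongside no change at the digits printed from compound 1 to compound 3 (within the scatter), this means that exchanges at two separate places on compound 1 have been read, and neither goes beyond the scatter; the claim holds only for these two exchanges, and the reading does not separate benzyl from 4-fluorophenyl at this position. Nothing at hand explains the flat reading, and no supporting measurement bears on this result.

Still open, going by these compounds, is whether an aliphatic amine or a carboxylic acid on this same aromatic carbon would also leave the number within the scatter of compound 1, since both groups compared here are single carbon-only aromatic rings with no hydrogen-bond donors or acceptors. Also open, on these data alone, is whether a longer chain linking the two amine nitrogens of the core of compound 1 would give a step beyond the scatter.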